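Removing the phenolic hydroxy from the weakest of three binders

A few compounds are considered here, and "the series" means these few. Any claim that something is new, unique, unknown or untested is made for them only; others in the source may bear on it.

Of the compounds shown here, three have been measured for displacement of a labelled ligand in an assay on HEK293 cells for displacement of a labelled ligand from Neuronal acetylcholine receptor; alpha3/beta4 (Homo sapiens), read by scintillation counting; a higher number here means a weaker inhibitor, a lower number a stronger inhibitor. Compound 1 `CN1CCC[C@H]1COc1cncc(O)c1` gives 235 nM, compound 3 `COc1ncccc1OC[C@@H]1CCCN1C` gives 793 nM, and compound 2 `COc1ccc(O)cc1OC[C@@H]1CCCN1` gives 7700 nM. Compound 2 stands at the highest number of the three: its gap to compound 3 and its larger gap to compound 1 both lie beyond the usual scatter, so compound 2 is the weakest binder among the three in this assay. Compound 1 and compound 3 differ from compound 2 in more than one place, so no single-change step can be read from them.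

Compound 4 `COc1ccccc1OC[C@@H]1CCCN1` is the not yet measured neighbour of compound 2. The difference is hydrogen in place of hydroxy on an aromatic carbon. Among the measured compounds shown here, nothing among the measured compounds isolates this change, so the expectation rests on the size of the group that leaves. Compound 4 is expected to sit close to compound 2, with the step of a 1.3-fold lower number from compound 2 to compound 4 (0.11 log units; within the scatter) estimated as small and within the scatter. For compound 4 the estimated inhibition constant is 6000 nM, with a range from 1500 nM to 20000 nM.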

Compound 4, inhibition constant: 3600 nM
Compound 4: the middle estimate sits 1.7-fold (0.22 log units) above what was measured, within the range that was stated.
By their numbers in this assay, from the lowest: compound 1; then compound 3; then compound 4; then compound 2.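

In this assay, among the compounds shown here, the first step that isolates a single change is the loss of the hydroxy from the aromatic carbon para to the methoxy group (a 2.1-fold lower number from compound 2 to compound 4 (0.33 log units; beyond the scatter)). The step is modest, but its direction shows that, in this pair, the hydroxy at this position is not needed for binding, since the number falls rather than rises when hydrogen takes its place. No measurement shown here explains why the number moves in this direction.

On these data alone, compound 2 and compound 4 compare only hydroxy with hydrogen, so it remains open whether fluorine, an amine or a carboxylic acid on this carbon would lower the number further or raise it. As far as these compounds go, whether the same exchange on the core of compound 1, which also carries a hydroxy, would give a step of similar size also remains open.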